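Trimethoxyphenyl Variant of a Chalcone–Macrolactam Hybrid

The compounds below may be only part of what the source reports. "The series", "measured", "known", "first", "only" and "open" are said of these compounds alone.

Three compounds have been measured in a functional assay on MCF7 cells (Homo sapiens) for antiproliferative activity; a higher number here means a weaker inhibitor, a lower number a stronger inhibitor:
compound 1 `COc1ccc(/C=C/C(=O)c2ccc(OCCn3cc(CN4C(=O)/C=C/C(C)(C)C/C=C(\C)CC/C=C/4C)nn3)cc2O)cc1` gives 2.85 ug/mL
compound 2 `COc1ccccc1/C=C/C(=O)c1ccc(OCCn2cc(CN3C(=O)/C=C/C(C)(C)C/C=C(\C)CC/C=C/3C)nn2)cc1O` gives 1.17 ug/mL
compound 3 `COc1ccc(/C=C/C(=O)c2ccc(OCCCN3C(=O)/C=C/C(C)(C)C/C=C(\C)CC/C=C/3C)cc2)cc1` gives 3.17 ug/mL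

In this assay compound 3 stands highest of the three numbers; its gap to compound 1 lies within the scatter, while compound 2 lies beyond it. Compound 4 `COc1cc(/C=C/C(=O)c2ccc(OCCCN3C(=O)/C=C/C(C)(C)C/C=C(\C)CC/C=C/3C)cc2)cc(OC)c1OC` differs from compound 3 by 3,4,5-trimethoxyphenyl in place of 4-methoxyphenyl on a double-bonded chain carbon bound to a double-bonded chain carbon. Among the compounds with values here, the only measured step, a 2.4-fold lower number from compound 1 to compound 2 (0.39 log units; beyond the scatter), was modest and concerns the core of compounds 1 and 2, which is not that of compound 3; no measured pair adds methoxy groups. That step bears only loosely on the present change, so no shift beyond the scatter is expected, with the direction uncertain. The estimate for compound 4 in this assay is 2.5 ug/mL, with a range from 1 ug/mL to 6.5 ug/mL. This estimate corresponds to an expected step of a 1.3-fold lower number from compound 3 to compound 4 (0.10 log units; within the scatter).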

Compound 4, half-maximal inhibitory concentration: 0.58 ug/mL
Beside the measured number, compound 4's estimate is 4.3-fold (0.63 log units) above it; measured number below the stated range.
By their numbers in this assay, from the lowest: compounds 4 and 2 (each within the scatter of the next); then compounds 1 and 3 (each within the scatter of the next).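

In this assay, within the data shown here, exchanging 4-methoxyphenyl for 3,4,5-trimethoxyphenyl gives a 5.5-fold lower number from compound 3 to compound 4 (0.74 log units; beyond the scatter), the first measured change on the core of compound 3 and the first to add methoxy groups. This place on a double-bonded chain carbon bound to a double-bonded chain carbon therefore affects the number on this core too, as it did on the other core in a 2.4-fold lower number from compound 1 to compound 2 (0.39 log units; beyond the scatter).

No available evidence accounts for the new result. From the compounds shown here alone, it remains open whether all three methoxy groups are needed, and whether an amine or a hydroxyl group on this ring would serve as well.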